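The source may report more compounds than this note shows. Statements on the series, on what has been measured and on what is new or still open speak of the compounds shown alone.

Measured so far:

compound 1, `C/C(=N/Nc1nc(-c2ccc(C#N)cc2)cs1)c1cccnc1`: 40%
compound 2, `N#Cc1ccc(-c2csc(N/N=C\c3cccc4ccccc34)n2)cc1`: 40%
compound 3, `Fc1ccc(-c2csc(N/N=C\c3cccs3)n2)cc1`: 40%

All three were run in an in vitro assay on BTI-TN-5B1-4 cells for inhibition of Amine oxidase [flavin-containing] A (Homo sapiens), read by Amplex Red, with a stated time of 15 min, tested at 100 uM; a lower number here means less inhibition, a higher number more inhibition at the concentration tested (going by the name of the read-out). In this assay compound 2 gives 40%, and compound 1 gives 40% and compound 3 gives 40%, so compound 2 stands level with both at the digits shown; none of the three is separated from another beyond the scatter. Among the measured compounds shown here, no pair among them differs in a single place, so no single-point step has been measured.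

The next compound is compound 4, `Fc1ccc(-c2csc(N/N=C\c3cccc4ccccc34)n2)cc1`. Its relation to compound 2 is fluoro in place of cyano on an aromatic carbon. Compound 3 already carries the fluoro group on its own phenyl ring and sits at the same level as compound 2, which gives no sign that this exchange moves the read-out. The step from compound 2 to compound 4 is therefore expected to be no change at the digits printed from compound 2 to compound 4 (within the scatter), i.e. nothing beyond the scatter. For compound 4 the expected value in this assay is 40%, with a range from 28% to 52%, because compound 2 gives 40%.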

Compound 4, a percentage reported as inhibition, at one concentration (the size of the read-out at that concentration, not a potency): 40%
Estimate against measurement, compound 4: no gap at the digits printed, within the range that was stated.
By their numbers in this assay, from the lowest: compounds 1, 2, 3 and 4 (each within the scatter of the next).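

The exchange on an aromatic carbon para to a large group is now a measured single-place step in this assay, giving no change at the digits printed from compound 2 to compound 4 (within the scatter) as the first step of this kind in the series. The read-out at this position therefore stays within the scatter when the nitrile, with its triple bond and hydrogen-bond acceptor, gives way to the smaller fluoro group, although this covers a single concentration and is no statement on potency. Nothing at hand bears on the reason for this result.

As far as these compounds go, whether an amine or a carboxylic acid at this position would shift the read-out remains open. From the compounds shown here alone, it is also open whether 4-cyanophenyl and 4-fluorophenyl would stay level in this assay on a core carrying a different hydrazone partner.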